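From a pyridine amide to a pyrimidine amide

The compounds below may be only part of what the source reports. "The series", "measured", "known", "first", "only" and "open" are said of these compounds alone.

Measured in a functional assay on A2780 cells (Homo sapiens) for antiproliferative activity, read by CellTiter-Glo, with a stated time of 4 days (a lower number here means a stronger inhibitor, a higher number a weaker inhibitor), so far:
compound 1 `CCC(=O)N[C@@H](C)c1ccc(NC(=O)[C@H]2C[C@@H]2c2cccnc2)cc1` gives 5 nM
compound 2 `C[C@H](NC(=O)c1ccccn1)c1ccc(NC(=O)[C@H]2C[C@@H]2c2cccnc2)cc1` gives 14 nM

Compound 2 holds the higher, and so weaker, of these two numbers. Within the data shown here, its only measured neighbour differs on a carbonyl carbon, where pyridin-2-yl stands in place of ethyl, and that exchange gave a 2.8-fold higher number from compound 1 to compound 2 (0.45 log units; beyond the scatter) as a modest step.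

Compound 3 (`C[C@H](NC(=O)c1ncccn1)c1ccc(NC(=O)[C@H]2C[C@@H]2c2cccnc2)cc1`) keeps the rest of the structure but carries pyrimidin-2-yl in place of pyridin-2-yl on that carbonyl carbon (pyrimidin-2-yl in place of pyridin-2-yl on a carbonyl carbon). Among the measured compounds shown here, the one measured step bears on this only indirectly. It replaced ethyl with a ring, whereas here one six-membered aromatic ring replaces another of equal heavy-atom count. For the measured compounds named here, no measured pair tests this exchange directly. A smaller change in structure suggests a step no larger than the modest one already seen, so in this assay the expected result is a 1.1-fold higher number from compound 2 to compound 3 (0.06 log units; within the scatter) and probably nothing beyond the scatter. For compound 3 the estimated value is 16 nM (expected range 6 nM to 40 nM).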

Compound 3, half-maximal inhibitory concentration in the A2780 assay: 14 nM
For compound 3 the middle estimate is 1.1-fold (0.06 log units) above the measured one; low and high end bracket the measured number.
By their numbers in the A2780 assay, from the lowest: compound 1; then compounds 2 and 3 (each within the scatter of the next).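

In the A2780 assay, putting pyrimidin-2-yl in place of pyridin-2-yl on this carbonyl carbon brings no change at the digits printed from compound 2 to compound 3 (within the scatter), and the distance from the ethyl compound stays as it was, with a 2.8-fold higher number from compound 1 to compound 3 (0.45 log units; beyond the scatter). So this position accepts a ring with 2 hetero atoms as readily as one with 1 hetero atom, although this rests on a single pair. The earlier compounds shown here could not show that such an exchange may matter for a different property. In a physicochemical assay for solubility, at pH 6.8 (a lower number here means a less soluble compound, a higher number a more soluble compound), compound 2 gives 10000 nM and compound 3 gives 27000 nM, so compound 3 is the more soluble of the pair, and the added ring nitrogen brings a gain there without any visible cost in cell activity: the measured solubility of compound 2, 10000 nM, and of compound 3, 27000 nM, a 2.7-fold higher number (0.43 log units; beyond the scatter)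

The compounds shown leave open whether an amine on the pyrimidin-2-yl ring, or a longer chain such as propyl in place of ethyl on the carbonyl carbon, could bring the number in the A2780 assay back towards that of compound 1 while keeping the solubility gain. One pair also cannot say whether the same ring exchange would act alike on another core.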